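A few compounds are considered here, and "the series" means these few. Any claim that something is new, unique, unknown or untested is made for them only; others in the source may bear on it.

Measured so far in this series:
Compound 1 `Cc1ccc(NC2=CC(=O)c3nc4n(c3C2=O)[C@H]2OC[C@@H](O)[C@H]2OC4)cc1C`: 2820 nM
Compound 2 `CCCN(CCC)C1=CC(=O)c2nc3n(c2C1=O)[C@H]1OC[C@@H](O)[C@H]1OC3`: > 16000 nM, a limit of the assay rather than a number
Compound 3 `O=C1C=C(Nc2cccc(F)c2)C(=O)c2c1nc1n2[C@H]2OC[C@@H](O)[C@H]2OC1`: 7030 nM

All three compounds share one core and differ only in the group attached to a double-bonded ring carbon. In a functional assay on ECa-109 cells for inhibition, with ECa-109 cell line (Homo sapiens) as the target, read by sulforhodamine B assay (on this read-out higher numbers stand for weaker inhibition and lower numbers for stronger inhibition), compound 1 gives 2820 nM. Compound 2 reaches only the limit > 16000 nM in this assay, so it has no number of its own (the limit of > 16000 nM in this assay, at which 1 of the 3 values shown sits). In this assay compound 3 gives 7030 nM, the higher and therefore weaker of the two numbers, as the step of a 2.5-fold higher number from compound 1 to compound 3 (0.40 log units; beyond the scatter) shows.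

Compound 4 `COc1ccccc1NC1=CC(=O)c2nc3n(c2C1=O)[C@H]1OC[C@@H](O)[C@H]1OC3` has not yet been measured. It differs from compound 3 in one place: 2-methoxyphenyl in place of 3-fluorophenyl on an amine nitrogen. For the measured compounds named here, the one measured step that also swaps a single aromatic ring on that amine nitrogen is a 2.5-fold higher number from compound 1 to compound 3 (0.40 log units; beyond the scatter), a modest shift. The step of an at least 5.6-fold higher number from compound 1 to compound 2 (0.75 log units; beyond the scatter) replaces the whole arylamine with dipropylamino and so says little about a ring-for-ring swap. Going by the values given here, since the one comparable swap moved the number only modestly, the expected step of a 1.3-fold lower number from compound 3 to compound 4 (0.11 log units; within the scatter) is small, in either direction, and may well lie within the scatter. Compound 4 is therefore expected to give about 5500 nM, somewhere between 2000 nM and 15000 nM.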

Compound 4, half-maximal inhibitory concentration: > 4000 nM
Compound 4: a limit, no number (the forecaster's own chance of this, stated with the estimate: 12%); the middle value is on the limit's open side.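

In this assay compound 4 stops at a limit of the assay rather than a number, making it the second compound here to do so: the limit of > 4000 nM in this assay, at which 1 of the 4 values shown sits. For the compounds shown here, this is the first sign that keeping an aromatic ring on the amine nitrogen does not by itself give a number in this assay, since until now only the dipropylamino compound had ended at a limit. Against compound 1 only a floor can be read (an at least 1.4-fold higher number from compound 1 to compound 4 (0.15 log units; that floor lies within the scatter)), so 2-methoxyphenyl is not firmly separated from 3,4-dimethylphenyl, and the steps to compound 3 and compound 2 cannot be read, which leaves 2-methoxyphenyl unranked against 3-fluorophenyl and dipropylamino.

From the compounds shown here alone, it stays open whether compound 4 sits close to compound 3 or is far weaker, and no cause for its limit can be drawn from these values. Going by these compounds, how a plain phenyl or a pyridine ring on the same amine nitrogen would read also remains unknown, as does whether any group there can give a clearly lower number than compound 1.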